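The source may hold more compounds than are shown below. What is called first, only, known or untested is meant among the compounds shown, and "the series" means these compounds.

Compound 3, with structure `CCCc1c(C(C)C)nc(C(C)C)c(C(C)O)c1-c1ccc(F)cc1O`, gives 8000 nM in an assay on isolated protein for binding affinity to Glucagon receptor (Homo sapiens); on this read-out higher numbers stand for weaker inhibition and lower numbers for stronger inhibition. Among the three measured compounds it carries the highest number. Compound 1, with structure `CCc1c(C(C)C)nc(C(C)C)c(C(C)O)c1-c1ccc(F)cc1O`, gives 5000 nM in this assay, and the step of a 1.6-fold higher number from compound 1 to compound 3 (0.20 log units; within the scatter) lies within the scatter. Compound 2, with structure `CCCc1c(C(C)C)nc(C(C)C)c(C(C)O)c1-c1ccccc1O`, gives 190 nM in this assay, and the step of a 42-fold higher number from compound 2 to compound 3 (1.62 log units; beyond the scatter) is the single large movement in the set.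

Compound 4, with structure `CCCCCc1c(C(C)C)nc(C(C)C)c(C(C)O)c1-c1ccc(F)cc1O`, differs from compound 3 by ethyl in place of hydrogen on a saturated chain carbon, three bonds along the chain from an aromatic carbon. Among the measured compounds shown here, the only measured step that bears on this change is the chain lengthening from compound 1 to compound 3, where a 1.6-fold higher number from compound 1 to compound 3 (0.20 log units; within the scatter) stayed within the scatter. The step from compound 2 to compound 3 concerns the fluoro group, which compound 4 keeps unchanged, so it offers no guide here. On that basis no movement beyond the scatter is expected for compound 4, and its number is expected to stay near that of compound 3, with no change at the digits printed from compound 3 to compound 4 (within the scatter). Compound 4 is therefore estimated at 8000 nM, within a range from 3000 nM to 25000 nM.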

Compound 4, half-maximal inhibitory concentration: 8000 nM
The estimate for compound 4 equals the measured number at the digits printed, within the range that was stated.
By their numbers in this assay, from the lowest: compound 2; then compounds 1, 3 and 4 (each within the scatter of the next).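

In this assay, among the compounds shown here, the earlier compounds had tested only a methyl added to this chain, whereas ethyl in place of hydrogen on a saturated chain carbon, three bonds along the chain from an aromatic carbon, gave no change at the digits printed from compound 3 to compound 4 (within the scatter). Measured over the larger change, going from the ethyl chain to the pentyl chain gave a 1.6-fold higher number from compound 1 to compound 4 (0.20 log units; within the scatter). With the fluoro group kept, the number therefore stayed within the scatter from ethyl through to pentyl at this position.

From the compounds shown here alone, it remains open whether a hexyl chain, or an amine or a carboxylic acid in place of the pentyl chain, would move the number, and whether pentyl would behave the same way without the fluoro group, where compound 2, with its propyl chain, gives 190 nM. Nothing available explains why the number stays flat along this chain.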